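This account rests on a few compounds, and the source may have more. Where it says the series, first, only, none or still open, it means among the compounds named here.

For the measured compounds named here, in a functional assay on NCI-H146 cells (Homo sapiens) for cytotoxicity, with a stated time of 48 h, in the presence of a further agent that is not named here (on this read-out lower numbers stand for an effect already at smaller amounts and higher numbers for an effect only at larger amounts of compound), compound 3 `CN(C)CC[C@H](CSc1ccccc1)Nc1ccc(S(=O)(=O)NC(=O)c2ccc(N3CCN(Cc4ccccc4-c4ccc(Cl)cc4)CC3)cc2)cc1` gives 78700 nM, the highest of the three numbers measured so far. Compound 1 `CN(C)CC[C@H](CSc1ccccc1)Nc1ccc(S(=O)(=O)NC(=O)c2ccc(N3CCN(Cc4ccccc4-c4ccc(Cl)cc4)CC3)cc2)cc1C(F)(F)F` gives 2460 nM, and compound 2 `CN(C)CC[C@H](CSc1ccccc1)Nc1ccc(S(=O)(=O)NC(=O)c2ccc(N3CCN(CC4=C(c5ccc(Cl)cc5)CCCCC4)CC3)cc2)cc1[N+](=O)[O-]` gives 51.9 nM. Compound 2 differs from the others in several places. Compound 4 `CN(C)CC[C@H](CSc1ccccc1)Nc1ccc(S(=O)(=O)NC(=O)c2ccc(N3CCN(Cc4ccccc4-c4ccc(Cl)cc4)CC3)cc2)cc1C(=O)C(F)(F)F` has (trifluoromethyl)carbonyl in place of hydrogen on an aromatic carbon of compound 3: (trifluoromethyl)carbonyl in place of hydrogen on an aromatic carbon. Going by the values given here, the one measured step that bears on this change is a 32-fold higher number from compound 1 to compound 3 (1.51 log units; beyond the scatter), with hydrogen in place of trifluoromethyl on that same carbon. Run in reverse, it points to a large step towards a lower number in this assay. The expected change is a 39-fold lower number from compound 3 to compound 4 (1.59 log units; beyond the scatter). For compound 4 the estimate is 2000 nM, within an expected range from 300 nM to 12000 nM.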

Compound 4, half-maximal effective concentration: 2010 nM
Beside the measured number, compound 4's estimate is 1.0-fold (0.00 log units) below it; the measured number falls inside the stated range.
By their numbers in this assay, from the lowest: compound 2; then compounds 4 and 1 (each within the scatter of the next); then compound 3.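

In this assay, a second group on this aromatic carbon also gives a large step towards a lower number (a 39-fold lower number from compound 3 to compound 4 (1.59 log units; beyond the scatter)), so such a step is no longer tied to trifluoromethyl alone. Exchanging trifluoromethyl for (trifluoromethyl)carbonyl changes the number only within the scatter (a 1.2-fold lower number from compound 1 to compound 4 (0.09 log units; within the scatter)), so this assay does not separate these two groups. No measurement here explains either step. Open, from the compounds shown here alone, is whether an amine or a nitrile on this carbon would also lower the number.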